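A few compounds are considered here, and "the series" means these few. Any claim that something is new, unique, unknown or untested is made for them only; others in the source may bear on it.

The measured compounds, one per line:

Compound 1, `C=CCc1ccc(OCCSC(=S)N[C@H]2CCOC2=O)c(OC)c1`, in a functional assay on MCF7 cells (Homo sapiens) for antiproliferative activity, read by MTT assay, with a stated time of 72 h (a lower number here means a stronger inhibitor, a higher number a weaker inhibitor), compound 1 gives > 64000 nM, which is a limit of the assay and not a number.
Compound 2, `O=C(CNc1ccc(F)cc1)N[C@H]1CCOC1=O`: in this assay compound 2 gives > 64000 nM, again a limit of the assay rather than a number.
Compound 3, `O=C1OCC[C@@H]1NC(=S)SCCOc1ccc(Cl)cc1`: in this assay compound 3 gives 50500 nM.

Compound 3 therefore stands as the only one of the three with a number at all; the other two sit at the limit of > 64000 nM in this assay, at which 2 of the 3 values shown sit. Even that single number places compound 3 among weak inhibitors in this assay, and no step between measured compounds is available to show how any change on the aromatic ring moves the read-out.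

The next compound, compound 4, `CC(=O)c1ccc(OCCSC(=S)N[C@H]2CCOC2=O)cc1`, differs from compound 3 in one place: acetyl in place of chloro on an aromatic carbon. Among the compounds with values here, with only weak or unreported activity across compounds 1, 2 and 3, and no measured step to lean on, the expectation is that the step from compound 3 to compound 4 in this assay, a 1.1-fold higher number from compound 3 to compound 4 (0.04 log units; within the scatter), stays within the usual scatter or drifts toward weaker inhibition. Compound 4 is accordingly estimated at 55000 nM in this assay, with a plausible range from 15000 nM to 120000 nM, and a real chance that only a limit is reported.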

Compound 4, half-maximal inhibitory concentration: > 64000 nM
Compound 4: a limit, no number; the forecaster's own chance of this, stated with the estimate: 45%; middle value at least 1.1-fold (0.06 log units) from the limit.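

In this assay, within the data shown here, the change of chloro to acetyl on an aromatic carbon, para to a large group, gives the first step that can be read at all: an at least 1.2-fold higher number from compound 3 to compound 4 (0.10 log units; that floor lies within the scatter). As far as these compounds go, compound 4 gives > 64000 nM, which is a limit of the assay and not a number, so the step has only a floor, its true size is unknown, and acetyl at this position shows no gain in inhibition over chloro. Among these compounds, compound 3 remains the only compound with a number, so this position still has no measured change of known size to its name, and the series as shown sits mostly at one ceiling: the limit of > 64000 nM in this assay, at which 3 of the 4 values shown sit.

From the compounds shown here alone, whether any other group on this aromatic carbon, such as fluoro, bromo, a nitrile, an amine or a carboxylic acid, would give a clear number in this assay stays open. Also open, going by these compounds, is whether a longer chain in the linker of the core of compound 3, with chloro kept in place, would move the read-out beyond the scatter.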